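The source may report more compounds than this note shows. Statements on the series, on what has been measured and on what is new or still open speak of the compounds shown alone.

Series notes. In a functional assay on the whole organism (strain Swiss) with Mus musculus as the target, in the maximal electroshock model, with a stated time of 0.25 h, at a dose of 100 mg/kg by the intraperitoneal route (a lower number here means a weaker effect, a higher number a stronger effect of the compound at the dose given), compound 1 `COCC(C(=O)N1CCN(c2cccc(C(F)(F)F)c2)CC1)N1C(=O)CCC1=O` gives 100%, and compound 3 `CC(C(=O)N1CCN(c2ccccc2C(F)(F)F)CC1)N1C(=O)CCC1=O` gives 100%. Compound 2 `CC(C(=O)N1CCN(c2ccc(Cl)cc2)CC1)N1C(=O)CCC1=O` gives 50% in this assay, the lowest of the three numbers; both compound 1 and compound 3 stand above it by a margin beyond the scatter. Among the compounds with values here, no single-point step between two measured compounds exists here, so the weight of any one group cannot be separated from the rest of the structure. Compound 4 `CC(C(=O)N1CCN(c2cccc(F)c2)CC1)N1C(=O)CCC1=O` differs from compound 2 as follows: 3-fluorophenyl in place of 4-chlorophenyl on an amine nitrogen in a ring. The expected step from compound 2 to compound 4 is upward, a number 20 percentage points higher from compound 2 to compound 4 (beyond the scatter), likely beyond the scatter but uncertain. Compound 4 is therefore estimated at 70% in this assay, within a range of 40% to 100%.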

Compound 4, a percentage reported as activity, at one dose (the size of the read-out at that dose, not a potency): 75%
Compound 4: the middle estimate sits 5 percentage points below what was measured; measured number inside the range.
By their numbers in this assay, from the lowest: compound 2; then compound 4; then compounds 1 and 3 (each within the scatter of the next).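

Within the data shown here, the first single-place step shows that the aryl group on the amine nitrogen in a ring can alone move the read-out in this assay: 3-fluorophenyl in place of 4-chlorophenyl gives a number 25 percentage points higher from compound 2 to compound 4 (beyond the scatter) with the heavy-atom count of the group unchanged. The halogen and its place on the phenyl ring change together, so the step belongs to the two changes jointly and to neither one alone. No data at hand account for the step.

Open, on these data alone, is whether 3-chlorophenyl or 4-fluorophenyl at this position would separate the halogen from its placement. Also open, as far as these compounds go, is how an unsubstituted phenyl or a methoxyphenyl compares on the same core.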